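Methylating a Ring Nitrogen of Compound 1

The source may report more compounds than this note shows. Statements on the series, on what has been measured and on what is new or still open speak of the compounds shown alone.

Compound 1 `COC(=O)NC1=NC(c2cccc(C)c2)CN1` at 100 mg/kg
Compound 2 `COC(=O)NC1=NC(c2cccc(F)c2)CN1` at 70 mg/kg
Compound 3 `COC(=O)NC1=NC(c2cccc(Br)c2)CN1` at about 68 mg/kg

In a functional assay on the whole organism for antagonist activity, with Mus musculus as the target, in the maximal electroshock model (a lower number here means that less compound is needed, a higher number that more compound is needed for the effect), compound 1 at 100 mg/kg lies within the scatter of the other two compounds. The change methyl in place of hydrogen on an amine nitrogen in a ring turns compound 1 into compound 4 `COC(=O)NC1=NC(c2cccc(C)c2)CN1C` and is methyl in place of hydrogen on an amine nitrogen in a ring. Among the compounds with values here, the measured steps of a 1.4-fold lower number from compound 1 to compound 2 (0.15 log units; within the scatter) and a 1.5-fold lower number from compound 1 to compound 3 (0.17 log units; within the scatter) stayed within the scatter but concern an aromatic carbon, so no measured step speaks directly to this nitrogen. In this assay no step beyond the scatter is therefore expected in either direction, though this is uncertain. The estimated step is a 1.2-fold higher number from compound 1 to compound 4 (0.08 log units; within the scatter) and carries a wide range. For compound 4 the estimated value is 120 mg/kg within an expected range of 50 mg/kg to 300 mg/kg as a rough guess.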

Compound 4, dose for half-maximal effect: 89 mg/kg
Beside the measured number, compound 4's estimate is 1.3-fold (0.13 log units) above it, and the stated range covers the measured number.
By their numbers in this assay, from the lowest: compounds 3, 2, 4 and 1 (each within the scatter of the next).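

The earlier steps shown here all concerned an aromatic carbon, whereas this one speaks directly to the amine nitrogen in the ring. In this assay, methyl in place of hydrogen on that nitrogen gives a 1.1-fold lower number from compound 1 to compound 4 (0.05 log units; within the scatter) and so stays within the scatter, which means that this single added carbon leaves the dose needed practically unchanged. No measurement at hand gives a reason for this result. As far as these compounds go, whether a longer chain such as propyl, or a benzyl group, would also stay within the scatter on this nitrogen remains open. So does the outcome of the same methyl change with the fluoro or bromo group of compound 2 and compound 3 on the aromatic carbon.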